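The compounds below may be only part of what the source reports. "The series", "measured", "known", "first", "only" and "open" are said of these compounds alone.

Of the compounds shown here, three sharing one core have been tested in a functional assay on A549 cells (Homo sapiens) for cytotoxicity, read by MTT assay, with a stated time of 48 h; a lower number here means a stronger inhibitor, a higher number a weaker inhibitor. Compound 1 `COc1ccc(N/C=C\C(=O)c2nc(-c3ccc(F)cc3)n3ccccc23)cc1OC` gives only a limit of the assay there, > 30000 nM. Compound 2 `O=C(/C=C\Nc1cnc2ccccc2c1)c1nc(-c2ccc(C(F)(F)F)cc2)n2ccccc12` likewise gives only a limit, > 30000 nM. Compound 3 `O=C(/C=C\Nc1cnc2ccccc2c1)c1nc(-c2ccccc2)n2ccccc12` also stops at a limit, > 30000 nM. The step from compound 2 to compound 3, hydrogen in place of trifluoromethyl on an aromatic carbon, is a step that the two limits leave unreadable from compound 2 to compound 3 and both of its ends rest at the limit of > 30000 nM in this assay, at which 3 of the 3 values shown sit. Compound 4 `O=C(/C=C\Nc1ccc(Cl)cc1)c1nc(-c2ccc(C(F)(F)F)cc2)n2ccccc12` differs from compound 2 by 4-chlorophenyl in place of quinolin-3-yl on an amine nitrogen. Going by the values given here, no measured step touches this change, and every value shown is a limit, so no direction can be read from them. Compound 4 is therefore expected to move little, a step that the limit leaves unreadable from compound 2 to compound 4, and to lie near 40000 nM, between 15000 nM and 150000 nM, most probably as a limit once more.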

Compound 4, half-maximal inhibitory concentration: 18500 nM
Compound 4: middle estimate off by 2.2-fold (0.33 log units), on the high side; the range from low to high includes it.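

In this assay, 4-chlorophenyl in place of quinolin-3-yl on the amine nitrogen gives an at least 1.6-fold lower number from compound 2 to compound 4 (0.20 log units; that floor lies within the scatter). Going by these compounds alone, compound 4 is the first compound here to give a number rather than a limit, so a change at this position can bring a measurable value, although the floor of this step lies within the scatter. The true size of the step stays unknown because compound 2 sits at a limit of the assay: the limit of > 30000 nM in this assay, at which 3 of the 4 values shown sit.

Going by these compounds, whether the chlorine matters, or the single carbon ring alone, remains open. The compounds shown include no 4-bromophenyl or cyclohexyl group on that amine nitrogen.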